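Pyrazolyl in Place of Bromo: Expected Cytotoxicity

The source may hold more compounds than are shown below. What is called first, only, known or untested is meant among the compounds shown, and "the series" means these compounds.

In an ADME assay on RD cells (Homo sapiens) for cytotoxicity (on this read-out higher numbers stand for lower toxicity in this test and lower numbers for higher toxicity in this test), the three measured compounds give:
Compound 1 `O=C1Nc2ccccc2/C1=N/NC(=S)Nc1ccccc1`: > 25000 nM, a limit of the assay.
Compound 2 `O=C1Nc2ccccc2/C1=N/NC(=S)Nc1ccc(F)cc1`: > 25000 nM, a limit of the assay.
Compound 3 `O=C1Nc2ccccc2/C1=N/NC(=S)Nc1ccc(Br)cc1`: > 25000 nM, a limit of the assay.

Compound 3 therefore stands at the limit of > 25000 nM in this assay, at which 3 of the 3 values shown sit, together with the two other measured compounds. None of the three steps among them can be read: the step that the two limits leave unreadable from compound 1 to compound 2, the step that the two limits leave unreadable from compound 1 to compound 3 and the step that the two limits leave unreadable from compound 2 to compound 3 are all hidden behind the same limit, so nothing is known about whether fluoro or bromo on the aromatic carbon changes the read-out at all.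

Compound 4 `O=C1Nc2ccccc2/C1=N/NC(=S)Nc1ccc(-n2cccn2)cc1` has not yet been measured. It differs from compound 3 by 1H-pyrazol-1-yl in place of bromo on an aromatic carbon. Among the measured compounds shown here, no measured step bears on this kind of change, and the steps that do exist are all unreadable. The only thing the shown values support is that the compounds so far have shown no measurable toxicity in this assay, and compound 4 is expected to sit at or beyond the same limit, with the step that the limit leaves unreadable from compound 3 to compound 4 expected to stay within the usual scatter. For compound 4 the estimate is 40000 nM, with a range from 15000 nM to 100000 nM.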

Compound 4, half-maximal cytotoxic concentration: > 25000 nM
Compound 4 was reported as a limit; the forecaster's own chance of this, stated with the estimate: 80%; the middle value does not contradict the limit.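

In this assay compound 4 gives > 25000 nM, a limit of the assay. Among the compounds shown here, no step from compound 1, compound 2 or compound 3 to compound 4 can be read, as all four compounds sit at one limit: the limit of > 25000 nM in this assay, at which 4 of the 4 values shown sit. The compounds shown leave open whether hydrogen, fluoro, bromo or 1H-pyrazol-1-yl on the aromatic carbon changes this read-out at all.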